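Swapping the Group on the Hydrazone Carbon

A few compounds are considered here, and "the series" means these few. Any claim that something is new, unique, unknown or untested is made for them only; others in the source may bear on it.

Going by the values given here, compound 2 `O=C(CSc1nnc(-c2ccncc2)o1)N/N=C/c1ccccc1[N+](=O)[O-]` gives 41600 nM in a functional assay on BGC-823 cells (Homo sapiens) for cytotoxicity, read by MTT assay, with a stated time of 48 h (on this read-out lower numbers stand for stronger inhibition and higher numbers for weaker inhibition), the highest of the two numbers measured so far; its nearest neighbour is compound 1 `Cc1ccc(/C=N/NC(=O)CSc2nnc(-c3ccncc3)o2)cc1`, which gives 21800 nM, and the step of a 1.9-fold higher number from compound 1 to compound 2 (0.28 log units; within the scatter) lies within the scatter. Compound 3 `O=C(CSc1nnc(-c2ccncc2)o1)N/N=C/c1cc(Cl)cc(Cl)c1O` has not yet been measured. It differs from compound 2 in one place: 3,5-dichloro-2-hydroxyphenyl in place of 2-nitrophenyl on a carbon with a double bond to nitrogen. Among the compounds with values here, the only measured step, which also exchanged the group on that same carbon, stayed within the scatter, so little movement is expected here, in no firm direction. Compound 3 is expected to give 30000 nM, within a range from 8000 nM to 110000 nM, a step of a 1.4-fold lower number from compound 2 to compound 3 (0.14 log units; within the scatter).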

Compound 3, half-maximal inhibitory concentration: 6340 nM
The estimate for compound 3 lay 4.7-fold (0.68 log units) above the measured number, and the stated range ends above it.
By their numbers in this assay, from the lowest: compound 3; then compounds 1 and 2 (each within the scatter of the next).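

Exchanging the group on the carbon with a double bond to nitrogen can move the number beyond the scatter: 3,5-dichloro-2-hydroxyphenyl in place of 2-nitrophenyl gives a 6.6-fold lower number from compound 2 to compound 3 (0.82 log units; beyond the scatter) and in place of 4-methylphenyl gives a 3.4-fold lower number from compound 1 to compound 3 (0.54 log units; beyond the scatter) in this assay on both counts. Compound 3 therefore has the lowest number of the three. No measurement available explains this gain. The compounds shown do not separate the contribution of the hydroxy group from that of the two chlorines. Going by these compounds, how a phenyl ring carrying an amine or a carboxylic acid would behave on this carbon also stays open.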